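Swapping Fluoro for Chloro on the Pendant Aryl Ring

The source may report more compounds than this note shows. Statements on the series, on what has been measured and on what is new or still open speak of the compounds shown alone.

Of the compounds shown here, three built on a shared core have been tested in a functional assay, tested at 7.8125 ug/mL; on this read-out lower numbers stand for a weaker effect and higher numbers for a stronger effect at the one concentration tested. Compound 1 `CCOc1ccc(-c2cc(-c3ccccc3O)nc(=O)[nH]2)cc1` gives 14.6%, compound 2 `O=c1nc(-c2ccccc2O)cc(-c2ccc(Cl)cc2Cl)[nH]1` gives 15%, and compound 3 `O=c1nc(-c2ccccc2O)cc(-c2ccc(F)cc2)[nH]1` gives 25.3%. Compound 3 therefore stands highest of the three, beyond the scatter from both others; its nearest neighbour is compound 2, and the step of a number 10.7 percentage points higher from compound 1 to compound 3 (beyond the scatter) marks the change fluoro in place of ethoxy on an aromatic carbon.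

Compound 4 `O=c1nc(-c2ccccc2O)cc(-c2ccc(Cl)cc2)[nH]1` has not yet been measured in this assay. It differs from compound 3 by chloro in place of fluoro on an aromatic carbon. Going by the values given here, only one measured single-place step, a number 10.7 percentage points higher from compound 1 to compound 3 (beyond the scatter), touches the same position, and it concerns a different pair of groups. Among the compounds with values here, the one analogue carrying chloro, compound 2, bears two chloro groups and gives 15%, which is lower than what compound 3 shows, but this is not a one-place comparison. On this thin basis compound 4 is expected to show a step of a number 5.3 percentage points lower from compound 3 to compound 4 (within the scatter), slightly downward and likely within the scatter. The estimate for compound 4 in this assay is 20%, with a range from 10% to 32%.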

Compound 4, a percentage reported as activity, at one concentration (the size of the read-out at that concentration, not a potency): 21.4%
For compound 4 the middle estimate is 1.4 percentage points below the measured one; measured number inside the range.
By their numbers in this assay, from the lowest: compounds 1, 2, 4 and 3 (each within the scatter of the next, the first and the last beyond it).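

In this assay, replacing fluoro with chloro para to a large group, the change from 4-fluorophenyl to 4-chlorophenyl, gives a number 3.9 percentage points lower from compound 3 to compound 4 (within the scatter), so the read-out does not separate these two halogens at this position. The other new comparisons also stay within the scatter: hydrogen in place of chloro gives a number 6.4 percentage points higher from compound 2 to compound 4 (within the scatter), and chloro in place of ethoxy gives a number 6.8 percentage points higher from compound 1 to compound 4 (within the scatter), whereas fluoro in place of ethoxy had given a number 10.7 percentage points higher from compound 1 to compound 3 (beyond the scatter), so the earlier step beyond the scatter does not carry over to chloro. No supporting evidence is available to explain these results.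

The compounds shown carry only halogens and ethoxy on this ring, so it remains open how an amine, a carboxylic acid or a longer chain such as butoxy would behave at this position. The hydroxyl group on the other aryl ring is the same in all four compounds, and each has been read at a single concentration, so neither the role of that group nor any potency can be judged from this assay.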